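The source may hold more compounds than are shown below. What is called first, only, known or untested is meant among the compounds shown, and "the series" means these compounds.

Measured so far in a functional assay on the whole organism (Tail, strain ICR) with Mus musculus as the target, in the tail flick test, with a stated time of 90 min, at a dose of 6.25 umol/kg by the oral route; on this read-out higher numbers stand for a stronger effect at the one dose given and lower numbers for a weaker effect:

- compound 1 `O=C(CN(c1nc(Cl)nc2[nH]cnc12)C1CC1)NCC(=O)OCc1ccccc1`: 9.93%
- compound 2 `N=C(N)NCCC[C@H](NC(=O)CN(c1nc(Cl)nc2[nH]cnc12)C1CC1)C(=O)O`: 12.1%

Compound 2 gives the higher of the two numbers, but the gap to compound 1 falls within the scatter, so the two compounds are not separated in this assay; both sit low on the read-out. Among the measured compounds shown here, no pair differing in one place has been measured, so no step size is known for the series.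

Compound 3 `CC(C)C[C@H](NC(=O)CN(c1nc(Cl)nc2[nH]cnc12)C1CC1)C(=O)O` is not yet measured. It departs from compound 2 as follows: a group of 3 heavy atoms (3 carbon; no ring) in place of a group of 6 heavy atoms (3 carbon, 3 nitrogen; no ring), on a saturated chain carbon, two bonds along the chain from an amide-type nitrogen and a carbonyl carbon.

For the measured compounds named here, no measured step in this assay supports a direction. With both measured compounds low and within the scatter of each other, no step beyond the scatter is expected from compound 2 to compound 3 in this assay, and the estimated step of a number 0.1 percentage points lower from compound 2 to compound 3 (within the scatter) is small. Compound 3 is accordingly expected at about 12%, between 3% and 25%.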

Compound 3, a percentage reported as activity, at one dose (the size of the read-out at that dose, not a potency): 16.2%
For compound 3 the middle estimate is 4.2 percentage points below the measured one, and the stated range covers the measured number.
By their numbers in this assay, from the lowest: compounds 1, 2 and 3 (each within the scatter of the next).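

In this assay, isopropyl in place of the group of 6 heavy atoms (3 carbon, 3 nitrogen), on a saturated chain carbon, gives a number 4.1 percentage points higher from compound 2 to compound 3 (within the scatter). Among the compounds shown here, this is the first step read at this position, and it shows that exchanging a larger, nitrogen-bearing group for a smaller, all-carbon one does not separate the two compounds on this read-out. No measurement of any property of these compounds bears on this step.

Still open, from the compounds shown here alone, is whether a different group at this position, such as a primary amine, a hydroxyl group or a longer chain, would give a step beyond the scatter. Also open, going by these compounds, is how the read-out responds to replacing the carboxylic acid shared by compound 2 and compound 3 with a methyl ester or a primary amide.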